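Swapping the Aryl Group on a Ring Nitrogen

The source may hold more compounds than are shown below. What is called first, only, known or untested is meant among the compounds shown, and "the series" means these compounds.

Of the compounds shown here, three have been measured in an in vitro functional assay on HEK293-A cells for negative allosteric modulation of metabotropic glutamate receptor 5 (Homo sapiens), read by FLIPR and calcium flux; on this read-out higher numbers stand for weaker inhibition and lower numbers for stronger inhibition. Compound 1 `O=c1oc2ccccc2n1Cc1nc(-c2cccc(Cl)c2)no1` gives 2100 nM. Compound 3 `O=c1sc2ccccc2n1Cc1nc(-c2cccc(Cl)c2)no1` gives 1100 nM. These two values lie within the scatter of each other, so no order between them can be read. Among the measured compounds shown here, compound 2 `O=C1CC(c2nc(-c3cccc(Cl)c3)no2)CN1c1ccc(Cl)c(Cl)c1` belongs to a different core, and for it this assay reports only a limit, > 10000 nM, not a number; it is the one value that sits at the limit of > 10000 nM in this assay, at which 1 of the 3 values shown sits. Compound 2 therefore stands at the weak end of what has been measured so far, with no exact position.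

Compound 4 `COc1cccc(N2CC(c3nc(-c4cccc(Cl)c4)no3)CC2=O)c1` has not yet been measured. It differs from compound 2 in one place: 3-methoxyphenyl in place of 3,4-dichlorophenyl on an amide-type nitrogen in a ring. For the measured compounds named here, no measured pair shows what this change does, and the two compounds of the other core, compound 1 and compound 3, share neither the ring nor the change, so they give no guidance on it. With compound 2 sitting only at a limit, the step from compound 2 to compound 4 in this assay can be expected to be small or none beyond the scatter, in either direction, which is what a step that the limit leaves unreadable from compound 2 to compound 4 means. Compound 4 is thus expected to give about 12000 nM, with a likely range from 3000 nM to 40000 nM.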

Compound 4, half-maximal inhibitory concentration: 690 nM
Estimate against measurement, compound 4: 17-fold (1.24 log units) above; the measured number lies below the stated range.
By their numbers in this assay, from the lowest: compounds 4, 3 and 1 (each within the scatter of the next, the first and the last beyond it). At a limit, above all of these: compound 2.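

In this assay, putting 3-methoxyphenyl in place of 3,4-dichlorophenyl on the amide-type nitrogen in a ring gives an at least 14-fold lower number from compound 2 to compound 4 (1.16 log units; beyond the scatter). This shows something that compound 1 and compound 3 could not: the aryl group at this position can decide whether this core gives a measurable number at all, even though the leaving and entering groups each have 8 heavy atoms and one six-membered aromatic ring of carbon only. For compound 2 the value is a limit, not a number, so the step has a floor but no exact size: the limit of > 10000 nM in this assay, at which 1 of the 4 values shown sits.

The change removes two chlorines and adds a methoxy group in a single move, and with no plain phenyl ring at this position among the compounds shown, it stays open whether losing the chlorines, gaining the methoxy group, or both, lies behind the step. From the compounds shown here alone, it is also open whether an ethoxy group or an amine in place of the methoxy group would keep the number of compound 4, and whether the same swap would do anything on the core of compound 1.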